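This account rests on a few compounds, and the source may have more. Where it says the series, first, only, none or still open, it means among the compounds named here.

Measured in a functional assay on HepG2 cells (Homo sapiens) for cytotoxicity, read by MTT assay, with a stated time of 48 h; a higher number here means a weaker inhibitor, a lower number a stronger inhibitor:
Compound 1 `CC1=NN(C(=O)c2ccc(C)cc2)C(c2ccccc2O)C1`: 11300 nM
Compound 2 `Cc1ccc(C(=O)N2N=C(c3cc4ccccc4oc3=O)CC2c2ccccc2)cc1`: 52300 nM

Of the two, compound 2 carries the higher number, 52300 nM, a gap to compound 1 that lies beyond the scatter. Compound 3 `O=C(CNC1CC1)N1N=C(c2cc3ccccc3oc2=O)CC1c1ccccc1` has not yet been measured. It carries (cyclopropylamino)methyl in place of 4-methylphenyl on a carbonyl carbon. For the measured compounds named here, no measured step shows what this change does, so the expectation is loose. A modest move toward a lower number in this assay is expected, with the estimated step being a 2.1-fold lower number from compound 2 to compound 3 (0.32 log units; beyond the scatter). The estimate for compound 3 is 25000 nM, with an expected range from 8000 nM to 80000 nM.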

Compound 3, half-maximal inhibitory concentration: "not active" (no number reported)
The entry for compound 3 holds no number; the estimate stays without a comparison.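

In this assay, for the compounds shown here, compound 3 is reported as not active with no number, so no step from compound 2 to compound 3 can be read. From the compounds shown here alone, how far (cyclopropylamino)methyl in place of 4-methylphenyl shifts the number stays open. Nothing shown here accounts for this result.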